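The compounds below may be only part of what the source reports. "The series", "measured", "known", "first", "only" and "open" are said of these compounds alone.

Measured so far:
compound 1 `Cc1cccc(C(=O)NCCC2CCN(S(=O)(=O)NC(=O)NC[C@@H]3C[C@@H]4C=C[C@@H]3C4)CC2)n1`: 20%
compound 2 `Cc1ncccc1C(=O)NCCC1CCN(S(=O)(=O)NC(=O)NC[C@@H]2C[C@@H]3C=C[C@@H]2C3)CC1`: 16%

Both numbers come from a functional assay on the whole organism (blood) with Rattus norvegicus as the target, with stated times of 24 h and 1 h, at a dose of 5 mg/kg by the intraperitoneal route; on this read-out lower numbers stand for a weaker effect and higher numbers for a stronger effect at the one dose given. Among the measured compounds shown here, compound 2 lies within the scatter of compound 1: the only measured step, a number 4 percentage points lower from compound 1 to compound 2 (within the scatter), does not move the read-out beyond what repeat measurements of this kind show.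

Compound 3 `COc1ccncc1C(=O)NCCC1CCN(S(=O)(=O)NC(=O)NC[C@@H]2C[C@@H]3C=C[C@@H]2C3)CC1` is not yet measured. It differs from compound 2 at the same place where compound 2 differs from compound 1, the group on the carbonyl carbon: 4-methoxypyridin-3-yl in place of 2-methylpyridin-3-yl on a carbonyl carbon. For the measured compounds named here, the one step that bears on a change at this place, a number 4 percentage points lower from compound 1 to compound 2 (within the scatter), stayed within the scatter, so exchanging the group on the carbonyl carbon has so far left the read-out unchanged. A step of similar size, that is none beyond the scatter, is therefore expected a number 2 percentage points higher from compound 2 to compound 3 (within the scatter). For compound 3 the estimate in this assay is 18%, with a range from 5% to 35%.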

Compound 3, a percentage reported as activity, at one dose (the size of the read-out at that dose, not a potency): 14%
Compound 3: middle estimate off by 4 percentage points, on the high side; the range from low to high includes it.
By their numbers in this assay, from the lowest: compounds 3, 2 and 1 (each within the scatter of the next).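

In this assay, replacing 2-methylpyridin-3-yl with 4-methoxypyridin-3-yl on the carbonyl carbon gives a number 2 percentage points lower from compound 2 to compound 3 (within the scatter), and replacing 6-methylpyridin-2-yl with the same group gives a number 6 percentage points lower from compound 1 to compound 3 (within the scatter). The position therefore now holds three different pyridinyl groups, including one with an added oxygen, and none of the listed steps goes beyond the scatter. No measurement is available that would explain this flat result.

On these data alone, all three compounds carry a pyridinyl group at this position and share the same remaining structure, so it remains open whether a phenyl group, or a pyridinyl group bearing a carboxylic acid or an amine, would shift the read-out beyond the scatter. A single dose also leaves open how these compounds would compare at other doses.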